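The compounds below may be only part of what the source reports. "The series", "measured", "known", "first", "only" and "open" are said of these compounds alone.

Compounds measured in a functional assay on HT-29 cells (Homo sapiens) for inhibition, read by MTT assay, with a stated time of 48 h; on this read-out lower numbers stand for stronger inhibition and higher numbers for weaker inhibition:
compound 1 `COc1cc(/C=C/c2ccc(NC(=O)/C=C/c3ccc([N+](=O)[O-])cc3)cc2)cc(OC)c1` — 10700 nM
compound 2 `COc1cc(/C=C/c2ccc(NC(=O)/C=C/c3ccc(O)c(O)c3)cc2)cc(OC)c1` — 1560 nM
compound 3 `COc1cc(/C=C/c2ccc(OC(=O)/C=C/c3ccccc3)cc2)cc(OC)c1` — 9050 nM

Compound 3 stands second highest of the three numbers. Its nearest neighbour is compound 1, whose number is higher by an amount within the scatter, so no order between compound 3 and compound 1 can be read. Compound 2 sits furthest away, at a lower number beyond the scatter.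

Compound 4 `COc1cc(/C=C/c2ccc(OC(=O)/C=C/c3ccc([N+](=O)[O-])cc3)cc2)cc(OC)c1` differs from compound 3 by the change nitro in place of hydrogen on an aromatic carbon: a hydrogen leaves and a nitro enters on an aromatic carbon of the six-membered ring of carbon only, para to a large group; read one bond further out, phenyl becomes 4-nitrophenyl.

For the measured compounds named here, no measured step adds a nitro to an unsubstituted phenyl. Going by the values given here, the single step available, a 6.9-fold lower number from compound 1 to compound 2 (0.84 log units; beyond the scatter), exchanges 4-nitrophenyl for 3,4-dihydroxyphenyl within the amide pair and says nothing direct about hydrogen against nitro. What can be used is the pair of compound 1 and compound 3: the nitrophenyl amide and the plain phenyl ester give numbers within the scatter of each other, which offers no hint of a large effect from the nitro in either direction. The step of a 1.1-fold higher number from compound 3 to compound 4 (0.04 log units; within the scatter) is therefore expected to stay within the scatter. For compound 4 the estimate in this assay is 10000 nM, with a range from 4000 nM to 25000 nM.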

Compound 4, half-maximal inhibitory concentration: > 20000 nM
Compound 4: a limit, no number; the forecaster's own chance of this, stated with the estimate: 5%; at least 2.0-fold (0.30 log units) between middle value and limit.
By their numbers in this assay, from the lowest: compound 2; then compounds 3 and 1 (each within the scatter of the next). At a limit, above all of these: compound 4.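

In this assay, nitro in place of hydrogen on an aromatic carbon, para to a large group, gives an at least 2.2-fold higher number from compound 3 to compound 4 (0.34 log units; beyond the scatter), the first step among these compounds that isolates this change, and it runs towards weaker inhibition. For the compounds shown here, the position on the phenyl ester is thus not indifferent to this substitution, which the earlier compounds could not show, since their only step exchanged 4-nitrophenyl for 3,4-dihydroxyphenyl in the amide pair. Compound 4 gives > 20000 nM, which is a limit of the assay and not a number, so the step has a lower bound but no known upper size, and its reading rests on this one limit value: the limit of > 20000 nM in this assay, at which 1 of the 4 values shown sits.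

On these data alone, what an amine or a carboxylic acid would give at this same position in the ester remains open, as does the result of a hydroxyl alone, so no trend across substituents can yet be drawn from hydrogen and nitro. As far as these compounds go, it is also open whether the 3,4-dihydroxyphenyl group, which in the amide compound 2 gives 1560 nM, would lower the number in the ester in the same way.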